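The source may hold more compounds than are shown below. What is called first, only, known or untested is meant among the compounds shown, and "the series" means these compounds.

Compound 1 `COc1nc(C)nc(/N=C(\C)c2ccccc2)n1`, compound 2 `COc1nc(C)nc(/N=C(\C)c2ccc(C)cc2)n1` and compound 3 `COc1ccc(/C(C)=N/c2nc(C)nc(OC)n2)cc1` are built on the same core and differ from one another at a single outer group. For compound 1, an ADME assay on Vero cells (Chlorocebus sabaeus) for cytotoxicity, read by MTT assay, with a stated time of 72 h (a lower number here means a stronger inhibitor, a higher number a weaker inhibitor), gives "not determined" (no result reported). In this assay compound 2 reaches only a limit of the assay, > 50 ug/mL. In this assay compound 3 likewise gives "not determined" (no result reported). Compound 3 therefore stands on no number of its own: among the three entries, one sits at a limit of > 50 ug/mL in this assay, at which 1 of the 3 values shown sits, and one further entry carries no number, so there is nothing against which compound 3 can be placed.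

Compound 4 `COc1nc(C)nc(/N=C(\C)c2ccc(O)cc2)n1` arises from compound 3 by one small change: hydrogen in place of methyl on an oxygen on an aromatic ring. Within the data shown here, no measured pair differs in just one place, so no step size has been observed; for the move from compound 3 to compound 4 in this assay the expectation is a change no larger than the usual scatter, in no set direction. Because compound 2 sits at the limit of > 50 ug/mL in this assay, at which 1 of the 3 values shown sits, the same outcome looks likely for compound 4. Compound 4 is expected to give 60 ug/mL, within a range of 30 ug/mL to 150 ug/mL, with a fair chance that only a limit is again reported.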

Compound 4, half-maximal inhibitory concentration: > 50 ug/mL
Compound 4: only a limit was reported; the forecaster's own chance of this, stated with the estimate: 75%; the middle value is on the limit's open side.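

In this assay compound 4 gives > 50 ug/mL, which is a limit of the assay and not a number. Compound 2 also gives only a limit, so no step can be read between compound 2 and compound 4. The compounds shown leave open how far any of these outer groups shifts the value, since none of the four carries a single number: the limit of > 50 ug/mL in this assay, at which 2 of the 4 values shown sit.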